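The compounds below may be only part of what the source reports. "The series", "measured", "known", "first", "only" and "open" are said of these compounds alone.

Measured compounds:
Compound 1, `CC1CCN(C2CCN(S(=O)(=O)c3ccccc3Br)CC2)CC1`, in a functional assay on DLD-1 cells (Homo sapiens) for antiproliferative activity, read by CellTiter-Glo, with a stated time of 72 h (a lower number here means a stronger inhibitor, a higher number a weaker inhibitor), gives 3 nM.
Compound 2, `CC1CCN(C2CCN(S(=O)(=O)c3ccccc3-c3ccccc3)CC2)CC1`, in this assay gives 0.96 nM.

Among the two compounds measured, compound 2 has the lower number, and the single step joining them, a 3.1-fold lower number from compound 1 to compound 2 (0.49 log units; beyond the scatter), lies beyond the scatter. The next compound, compound 3, `CC1CCN(C2CCN(S(=O)(=O)c3ccccc3-c3ccc(Cl)cc3)CC2)CC1`, differs from compound 2 in one place: chloro in place of hydrogen on an aromatic carbon, the chloro sitting on the outer ring that entered in the step from compound 1 to compound 2. Among the measured compounds shown here, no measured pair shows this particular change, so the only step that bears on it is the exchange of bromo for phenyl, a change of a different kind from adding a single chlorine to that new ring. On that basis no step beyond the scatter is expected in this assay for compound 3. The step expected from compound 2 to compound 3 is a 1.0-fold higher number from compound 2 to compound 3 (0.02 log units; within the scatter). Compound 3 is therefore estimated at 1 nM, with a likely range from 0.35 nM to 3 nM.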

Compound 3, half-maximal inhibitory concentration: 202 nM
Compound 3: middle estimate off by 200-fold (2.31 log units), on the low side; the whole stated range lies below it.
By their numbers in this assay, from the lowest: compound 2; then compound 1; then compound 3.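

In this assay, among the compounds shown here, putting one chloro in place of hydrogen on the phenyl ring, para to a large group, gives a 210-fold higher number from compound 2 to compound 3 (2.32 log units; beyond the scatter) and this is the largest step so far. For the compounds shown here, the earlier step showed only that a phenyl group is accepted in place of bromo; it gave no sign that a single added atom on that phenyl could matter this much. The 4-chlorophenyl group also does far worse than the bromo it replaces, with a 67-fold higher number from compound 1 to compound 3 (1.83 log units; beyond the scatter) and so the small gain from phenyl is more than lost.

Nothing shown here gives a reason for this loss. Going by these compounds, whether it belongs to chlorine itself or to any group at that place stays open, and a fluoro, methyl or methoxy group at the same carbon would help tell these apart.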